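The compounds below may be only part of what the source reports. "The series", "measured", "known", "first", "only" and "open" are said of these compounds alone.

Among the measured compounds shown here, compound 3 `COc1ccc(C(=O)NC(N/C(=N/C#N)Nc2ccccc2C)C(C)(C)C)cc1` gives 2510 nM in a functional assay on HEK293 cells for antagonist activity at P2X purinoceptor 7 (Rattus norvegicus), read by FLIPR and calcium flux (a lower number here means a stronger inhibitor, a higher number a weaker inhibitor), the highest of the three numbers known so far; nearest is compound 2 `Cc1ncccc1N/C(=N\C#N)NC(NC(=O)CCCCc1ccccc1)C(C)(C)C` with 50.1 nM, and compound 1 `Cc1ccccc1N/C(=N\C#N)NC(NC(=O)CCCc1ccccc1)C(C)(C)C` with 25.1 nM sits furthest away. For the measured compounds named here, the single one-point step recorded, a 100-fold higher number from compound 1 to compound 3 (2.00 log units; beyond the scatter), separates a carbonyl carbon carrying 3-phenylpropyl from one carrying 4-methoxyphenyl. Compound 4 `COc1ccc(C(=O)NC(N/C(=N/C#N)Nc2ccccc2C)C(C)(C)C)cc1OC` carries a further change on that aryl amide: methoxy in place of hydrogen on an aromatic carbon. Going by the values given here, no measured pair shows a methoxy added to an aromatic carbon, so that step bears only indirectly, marking the aryl amide as the weak side of the series. For compound 4 the expected step in this assay is a 1.0-fold lower number from compound 3 to compound 4 (0.00 log units; within the scatter), within the scatter. Compound 4 is estimated at 2500 nM, with a range from 1000 nM to 6300 nM.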

Compound 4, half-maximal inhibitory concentration: 631 nM
Beside the measured number, compound 4's estimate is 4.0-fold (0.60 log units) above it; measured number outside the range, below it.
By their numbers in this assay, from the lowest: compounds 1 and 2 (each within the scatter of the next); then compound 4; then compound 3.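

In this assay the added methoxy, ortho to a methoxy group, gives a 4.0-fold lower number from compound 3 to compound 4 (0.60 log units; beyond the scatter), so this aromatic carbon of the aryl amide responds to substitution. The change recovers only part of the ground lost on the aryl amide: 3,4-dimethoxyphenyl in place of 3-phenylpropyl still gives a 25-fold higher number from compound 1 to compound 4 (1.40 log units; beyond the scatter). No measurement offered here bears on the reason for this step.

From the compounds shown here alone, whether a hydroxy, a fluorine or an amine on the same carbon would give a similar step remains open. Also open, going by these compounds, is whether the 3,4-dimethoxyphenyl group would keep its step at the end of a longer chain, such as a propyl linker to the carbonyl.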